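Ring-methyl step on the azepane thiosemicarbazone, compound 4

This account rests on a few compounds, and the source may have more. Where it says the series, first, only, none or still open, it means among the compounds named here.

Measured so far:
compound 1 `N/C(=N\NC(=S)N1CCCCCC1)c1ccccn1` gives 84%
compound 2 `N/C(=N\NC(=S)N1CCCCC1)c1ccccn1` gives 77.7%
compound 3 `Cc1cccc(/C(N)=N/NC(=S)N2CCCCC2)n1` gives 54%

In a functional assay on MCF7 cells (Homo sapiens) for cytotoxicity, read by MTT assay, with a stated time of 72 h, tested at 100 uM (a higher number here means more inhibition of growth at the concentration tested, a lower number less inhibition of growth), compound 1 stands at 84%; the value of compound 2, 77.7%, lies within the scatter of it, so no order between the two can be claimed, while compound 3 at 54% lies clearly lower. The unmeasured compound 4 `Cc1ccnc(/C(N)=N/NC(=S)N2CCCCCC2)c1` differs from compound 1 by methyl in place of hydrogen on an aromatic carbon.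

Within the data shown here, one measured step bears on this change: a number 23.7 percentage points lower from compound 2 to compound 3 (beyond the scatter), the same kind of replacement on the same ring, though there the methyl sits elsewhere on the ring and on the piperidine rather than the azepane partner. That step was modest and beyond the scatter. Among the measured compounds shown here, with only one such step, and at a different place, the expectation for compound 4 is a drop of similar direction but uncertain size, a number 14 percentage points lower from compound 1 to compound 4 (beyond the scatter). Compound 4 is therefore estimated at 70%, with a range from 50% to 88%.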

Compound 4, percent growth inhibition at one concentration: 65.4%
Compound 4: middle estimate off by 4.6 percentage points, on the high side; low and high end bracket the measured number.
By their numbers in this assay, from the lowest: compound 3; then compound 4; then compounds 2 and 1 (each within the scatter of the next).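

In this assay, methyl in place of hydrogen, here opposite the ring nitrogen and meta to a large group, again lowers growth inhibition, now on a second core, with a number 18.6 percentage points lower from compound 1 to compound 4 (beyond the scatter). The loss is therefore not tied to a single ring place or a single core, and its size holds across the two cases: the same change on two cores in this assay, a number 23.7 percentage points lower (beyond the scatter) from compound 2 to compound 3 and a number 18.6 percentage points lower (beyond the scatter) from compound 1 to compound 4, 5.1 percentage points apart, within the scatter of two such steps The step stays modest, and compound 4 still gives 65.4%.

On these data alone, what a methoxy group, a chlorine atom or an amine would do on this same carbon stays open, so the drop cannot yet be assigned to methyl specifically rather than to any group placed there. Also open, as far as these compounds go, is whether the step would keep its size on other cores or at lower concentrations.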